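The compounds below may be only part of what the source reports. "The series", "measured", "known", "first", "only" and "open" are said of these compounds alone.

Compound 1 `C=CC[C@H]1C[C@]2([C@H](C)Cc3ccc(OC)c(OC)c3)OCOC2=CC1=O` is one of two measured compounds. Among the compounds with values here, in a functional assay on M14 cells (Homo sapiens) for antiproliferative activity, with a stated time of 72 h (a lower number here means a stronger inhibitor, a higher number a weaker inhibitor), compound 1 gives 300 nM, the only plain number reported here. Compound 2 `C=CC[C@@H]1C[C@]2([C@H](C)Cc3ccc(OC)c(OC)c3)OCOC2=CC1=O` has the same atoms and bonds as compound 1 and differs only in the configuration drawn at one saturated ring carbon. In this assay compound 2 gives only a limit, > 4000 nM. The step of an at least 13-fold higher number from compound 1 to compound 2 (1.12 log units; beyond the scatter) is large, and it goes with the fact that compounds 1 and 2 differ only in the configuration as drawn and with the limit of > 4000 nM in this assay, at which 1 of the 2 values shown sits.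

Compound 3 `C=CC[C@H]1C[C@]2([C@H](C)Cc3ccc(OC)cc3)OCOC2=CC1=O` differs from compound 1 in another way: hydrogen in place of methoxy on an aromatic carbon. Its configuration is drawn as in compound 1. Within the data shown here, no measured step concerns a change on the aromatic ring; the single measured step, an at least 13-fold higher number from compound 1 to compound 2 (1.12 log units; beyond the scatter), concerns configuration only and does not bear on this change. The expected step of a 1.3-fold higher number from compound 1 to compound 3 (0.12 log units; within the scatter) is therefore set within the usual scatter, in no clear direction, with a wide range for the uncertainty. Compound 3 is estimated at 400 nM, between 150 nM and 1500 nM.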

Compound 3, half-maximal inhibitory concentration: 81 nM
Compound 3: the middle estimate sits 4.9-fold (0.69 log units) above what was measured; the whole stated range lies above it.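

In this assay, replacing methoxy with hydrogen on this aromatic carbon gives a 3.7-fold lower number from compound 1 to compound 3 (0.57 log units; beyond the scatter), so the simpler compound is the stronger inhibitor. For this pair, the methoxy at this position is therefore not needed for antiproliferative activity, and removing it improves the result, while the other methoxy on the ring stays in place. Nothing known here explains this gain, since the available facts concern only the configuration at a saturated ring carbon and not the aromatic ring.

As far as these compounds go, it remains open whether hydrogen itself matters, since a fluorine atom, a hydroxyl group or an amine on this carbon could give a different number. Also open, from the compounds shown here alone, is whether the remaining methoxy can be replaced in the same way, and whether this change would have any similar result with the configuration drawn in compound 2.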